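This account rests on a few compounds, and the source may have more. Where it says the series, first, only, none or still open, it means among the compounds named here.

Working notes on the series. Compound 1 `NC(=O)c1cccc(Cn2cc(-c3ccc4cn[nH]c4c3)ccc2=O)c1` in an assay for inhibition of MAP kinase-interacting serine/threonine-protein kinase 2 (Homo sapiens), read by luminescence and ADP-Glo, with a stated time of 2 h (on this read-out lower numbers stand for stronger inhibition and higher numbers for weaker inhibition), gives 106 nM. Compound 2 `O=c1ccc(-c2ccc3cn[nH]c3c2)cn1Cc1cccc(C(F)(F)F)c1` in this assay gives 32 nM. The change between them is trifluoromethyl in place of carbamoyl on an aromatic carbon, and the step is a 3.3-fold lower number from compound 1 to compound 2 (0.52 log units; beyond the scatter).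

Compound 3 `NC(=O)c1ccc(Cn2cc(-c3ccc4cn[nH]c4c3)ccc2=O)cc1` in this assay gives only a limit, > 2000 nM; it is a limit and not a number (the limit of > 2000 nM in this assay, at which 1 of the 3 values shown sits). The difference between the core of compound 3 and the core of compound 1 is not broken down here.

Compound 4 `O=c1ccc(-c2ccc3cn[nH]c3c2)cn1Cc1ccc(C(F)(F)F)cc1` differs from compound 3 by trifluoromethyl in place of carbamoyl on an aromatic carbon. The place differs from the earlier case: there it was meta to a large group, here it is para to a large group, so this is the same kind of change, not the same change. A step resembling a 3.3-fold lower number from compound 1 to compound 2 (0.52 log units; beyond the scatter) is expected here. That expected step is estimated as an at least 1.6-fold lower number from compound 3 to compound 4 (0.22 log units; that floor lies within the scatter), resting on that one measured pair, with a starting point that is only a limit. For compound 4 the expected value in this assay is 1200 nM, estimated between 250 nM and 6000 nM.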

Compound 4, half-maximal inhibitory concentration: 1110 nM
Compound 4: middle estimate off by 1.1-fold (0.03 log units), on the high side; the measured number falls inside the stated range.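

Set side by side in this assay, trifluoromethyl in place of carbamoyl gives a lower number on both cores: the same change on two cores in this assay, a 3.3-fold lower number (0.52 log units; beyond the scatter) from compound 1 to compound 2 and an at least 1.8-fold lower number (0.25 log units; that floor lies within the scatter) from compound 3 to compound 4; the limit leaves it open whether they differ. The new step, an at least 1.8-fold lower number from compound 3 to compound 4 (0.25 log units; that floor lies within the scatter), is only a floor, so the data do not show whether the size of the change carries from one core to the other. Compound 3 gives > 2000 nM, which is a limit and not a number.

Still open, as far as these compounds go, is how a nitrile, an amine or a carboxylic acid on that aromatic carbon would compare with carbamoyl and trifluoromethyl on either core. Also open, from the compounds shown here alone, is whether such groups would keep the same direction of change on both cores.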